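Swapping a Chlorofluorophenyl Ring for a Cyanopyridine

The compounds below may be only part of what the source reports. "The series", "measured", "known", "first", "only" and "open" are said of these compounds alone.

Of the compounds shown here, two have so far been measured in a functional assay on MCF7 cells (Homo sapiens) for cytotoxicity, read by CellTiter-Glo, with a stated time of 5 days; on this read-out lower numbers stand for stronger inhibition and higher numbers for weaker inhibition. Compound 1 `CC/C(=C(/c1ccc(/C=C/C(=O)O)cc1)c1ccc2[nH]ncc2c1C#N)c1ccccc1` gives 1.5 nM in this assay, and compound 2 `O=C(O)/C=C/c1ccc(/C(=C(\c2ccc(F)cc2Cl)C2CCC2)c2ccc3[nH]nc(F)c3c2)cc1` gives 2 nM. The two numbers lie within the scatter of each other, so compound 2 cannot be told apart from compound 1 on this evidence. Compound 3 `N#Cc1cc(Cl)cnc1/C(=C(\c1ccc(/C=C/C(=O)O)cc1)c1ccc2[nH]nc(F)c2c1)C1CCC1` has not yet been measured. It differs from compound 2 in one place: 5-chloro-3-cyanopyridin-2-yl in place of 2-chloro-4-fluorophenyl on a double-bonded chain carbon bound to a double-bonded chain carbon and a saturated ring carbon. Going by the values given here, no measured pair here shows what such a swap does, so there is no step on record to lean on. Given that compound 2 stands at 2 nM, the change is expected to bring a small step at most, likely none beyond the scatter, in either direction. The estimate for compound 3 is 3 nM, with an expected range from 1 nM to 10 nM. The expected step is a 1.5-fold higher number from compound 2 to compound 3 (0.18 log units; within the scatter).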

Compound 3, half-maximal inhibitory concentration: 1.1 nM
Compound 3: the middle estimate sits 2.7-fold (0.44 log units) above what was measured; measured number inside the range.
By their numbers in this assay, from the lowest: compounds 3, 1 and 2 (each within the scatter of the next).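

Across the swap of 2-chloro-4-fluorophenyl for 5-chloro-3-cyanopyridin-2-yl, this assay shows a 1.8-fold lower number from compound 2 to compound 3 (0.26 log units; within the scatter), the first one-place step on record in this series. This position, on a double-bonded chain carbon bound to a double-bonded chain carbon and a saturated ring carbon, therefore accepts a six-membered aromatic ring with a hetero atom and a nitrile, with no change that can be told from the scatter. Nothing shown here explains why the number holds through this swap.

The ring nitrogen, the nitrile and the new placing of the chlorine all enter together, so their separate contributions cannot be pulled apart. Also open, as far as these compounds go, is whether the same position would hold its number with a methoxy group or an amine on the ring in place of the nitrile.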